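Swapping the chain at the aromatic nitrogen for a methoxyethyl

The source may hold more compounds than are shown below. What is called first, only, known or untested is meant among the compounds shown, and "the series" means these compounds.

Measured compounds:
compound 1, `COc1cc(Cc2nc3c(N)ncnc3n2CC(C)C)cc(OC)c1OC` — 97700 nM
compound 2, `CCCCCn1c(Cc2cc(OC)c(OC)c(OC)c2)nc2c(N)ncnc21` — 61700 nM

In a functional assay on MCF7 cells (Homo sapiens) for antiproliferative activity (on this read-out higher numbers stand for weaker inhibition and lower numbers for stronger inhibition), compound 1 gives 97700 nM and compound 2 gives 61700 nM. Among the measured compounds shown here, the only step between them, a 1.6-fold lower number from compound 1 to compound 2 (0.20 log units; within the scatter), shows that lengthening the saturated chain on the aromatic nitrogen leaves the read-out essentially unchanged. Compound 2 therefore stands at a weak level, with compound 1 within the scatter of it.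

Compound 3, `COCCn1c(Cc2cc(OC)c(OC)c(OC)c2)nc2c(N)ncnc21`, is the next compound on this chain: methoxy in place of propyl on a saturated chain carbon, two bonds along the chain from an aromatic nitrogen. For the measured compounds named here, the one measured step that bears on this change is the chain variation from compound 1 to compound 2, and it was within the scatter. Nothing measured here speaks to an oxygen in the chain, so the expectation rests on that single step alone. Compound 3 is expected to stay close to compound 2 in this assay, with a step of a 1.1-fold higher number from compound 2 to compound 3 (0.05 log units; within the scatter) and no movement beyond the scatter. Compound 3 is estimated at 70000 nM, within a range from 25000 nM to 200000 nM.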

Compound 3, half-maximal inhibitory concentration: 64600 nM
Compound 3: the middle estimate sits 1.1-fold (0.03 log units) above what was measured; low and high end bracket the measured number.
By their numbers in this assay, from the lowest: compounds 2, 3 and 1 (each within the scatter of the next).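

In this assay, the step of a 1.0-fold higher number from compound 2 to compound 3 (0.02 log units; within the scatter) shows that this position tolerates methoxy in place of propyl on a saturated chain carbon, two bonds along the chain from an aromatic nitrogen: a chain carrying one hydrogen-bond acceptor reads the same, within the scatter, as the all-carbon pentyl chain. The second step, a 1.5-fold lower number from compound 1 to compound 3 (0.18 log units; within the scatter), also stays within the scatter, so all three chains shown on the aromatic nitrogen give indistinguishable numbers, and the oxygen adds no measurable movement to what the carbon chains had already shown. No supporting data are available to explain this flat result.

On these data alone, whether an amine or a carboxylic acid at the end of this chain, or a much longer chain, would move the number beyond the scatter remains open. All three compounds share the rest of their structure, so these numbers do not tell how the read-out would respond to a change anywhere other than this chain.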